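This account rests on a few compounds, and the source may have more. Where it says the series, first, only, none or still open, it means among the compounds named here.

Working notes on the series. All compounds share one core; compound 3 `CCc1nn2c(-c3c(C)cc(OC)cc3OC)cccc2c1N(CC1CCOCC1)CC1CC1` gives 40 nM in an assay on HEK293 cells for displacement of a labelled ligand from corticotropin-releasing factor receptor 1 (Homo sapiens), read by scintillation counting, with a stated time of 2 h (a lower number here means a stronger inhibitor, a higher number a weaker inhibitor), the lowest of the three numbers recorded. Compound 1 `CCc1nn2c(-c3c(COC)cc(OC)cc3OC)cccc2c1N(CC1CCOCC1)CC1CC1` gives 120 nM in this assay, and compound 2 `COCc1cc(OC)c(-c2cccc3c(N(CC4CCOCC4)CC4CC4)c(C)nn23)c(OC)c1` gives 120 nM; these two values sit within the scatter of each other, so nothing separates them. Within the data shown here, the single step that can be followed is a 3.0-fold lower number from compound 1 to compound 3 (0.48 log units; beyond the scatter), a gain beyond the scatter but of modest size.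

Compound 4 `CCc1nn2c(-c3c(OC)cccc3OC)cccc2c1N(CC1CCOCC1)CC1CC1` differs from compound 3 by 2,6-dimethoxyphenyl in place of 2,4-dimethoxy-6-methylphenyl on an aromatic carbon. Among the measured compounds shown here, no measured pair alters the aryl in this way: the one step on that ring, a 3.0-fold lower number from compound 1 to compound 3 (0.48 log units; beyond the scatter), concerns only the methoxymethyl. For the measured compounds named here, removing two groups from the aryl at once has no precedent among the three measured compounds, so the expectation carries wide uncertainty; the step of a 3.8-fold higher number from compound 3 to compound 4 (0.57 log units; beyond the scatter) is expected to run toward a higher number, comparable in size to the one measured step. Compound 4 is therefore estimated at 150 nM, with a range from 40 nM to 600 nM.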

Compound 4, half-maximal inhibitory concentration: 105 nM
Beside the measured number, compound 4's estimate is 1.4-fold (0.15 log units) above it; the range from low to high includes it.
By their numbers in this assay, from the lowest: compound 3; then compounds 4, 1 and 2 (each within the scatter of the next).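

In this assay, among these compounds, replacing the whole aryl group on this aromatic carbon, and not only its methoxymethyl, also shifts the number: the change gives a 2.6-fold higher number from compound 3 to compound 4 (0.42 log units; beyond the scatter) in the same modest range as the one earlier step. Compound 4 (105 nM) lies within the scatter of compound 1 (120 nM), so 2,6-dimethoxyphenyl does not separate from the methoxymethyl-bearing aryl, while the 2,4-dimethoxy-6-methylphenyl of compound 3 stands apart from both. No supporting data bear on the origin of this step.

From the compounds shown here alone, the methyl and one methoxy leave the aryl together in this pair, so their separate shares in the step remain open. Going by these compounds, how an aminomethyl group or a carboxylic acid in place of that methyl would read also remains open.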